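Carboxy for amino at the chain end of a carbonate

The source may hold more compounds than are shown below. What is called first, only, known or untested is meant among the compounds shown, and "the series" means these compounds.

Compound 1 `Cc1cn(C2CC(N=[N+]=[N-])C(COC(=O)OCCCCO)O2)c(=O)[nH]c1=O` gives -0.68 in a physicochemical assay for lipophilicity; a lower number here means a more polar compound, a higher number a more lipophilic compound. Compound 2 `CCCCOC(=O)OCC1OC(n2cc(C)c(=O)[nH]c2=O)CC1N=[N+]=[N-]` gives 1.02 in this assay. Compound 3 `Cc1cn(C2CC(N=[N+]=[N-])C(COC(=O)OCCCN)O2)c(=O)[nH]c1=O` gives -0.93 in this assay.

Compound 3 stands lowest of the three numbers, with compound 1 nearest (a number 0.25 log units lower from compound 1 to compound 3 (within the scatter)) and compound 2 furthest (a number 1.95 log units lower from compound 2 to compound 3 (beyond the scatter)). Compound 4 `Cc1cn(C2CC(N=[N+]=[N-])C(COC(=O)OCCCC(=O)O)O2)c(=O)[nH]c1=O` is not yet measured in this assay. It differs from compound 3 in one place: carboxy in place of amino on a saturated chain carbon, three bonds along the chain from an oxygen next to a carbonyl group.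

For the measured compounds named here, no measured step swaps amino for carboxy, so the bearing is indirect. The step of a number 1.95 log units lower from compound 2 to compound 3 (beyond the scatter) shows that a group with a donor and an acceptor in place of methyl on this chain carbon moves the number a long way, and the step of a number 0.25 log units lower from compound 1 to compound 3 (within the scatter) shows that two such groups, hydroxy and amino, at this end of the chain land within the scatter of one another. Carboxy brings one donor and one acceptor, as amino does, so compound 4 is expected to stay close to compound 3, with no step beyond the scatter in this assay; the expected step is a number 0.13 log units higher from compound 3 to compound 4 (within the scatter). Compound 4 is therefore estimated at -0.8 in this assay, in a range from -1.5 to -0.1.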

Compound 4, partition coefficient: -0.55
Estimate against measurement, compound 4: 0.25 log units below; the range from low to high includes it.
By their numbers in this assay, from the lowest: compounds 3, 1 and 4 (each within the scatter of the next, the first and the last beyond it); then compound 2.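

In this assay, this place on the chain does respond to the exchange of amino for carboxy (a number 0.38 log units higher from compound 3 to compound 4 (beyond the scatter)), even though the computed hydrogen-bond donor and acceptor entries for the leaving and entering groups match. The separation is only partial, since compound 4 cannot be told apart from the hydroxymethyl-ended compound 1 (a number 0.13 log units higher from compound 1 to compound 4 (within the scatter)), just as compound 1 could not be told apart from compound 3, so the three compounds form a run in which only the two ends are separated, and all of them stay far from the methyl-ended compound 2, with carboxy also giving a large step (a number 1.57 log units lower from compound 2 to compound 4 (beyond the scatter)). Nothing available accounts for the size of any of these steps.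

The compounds shown leave open whether the gap between amino and carboxy persists on a longer or a shorter chain, where the same exchange might read differently. They also leave open how a methyl ester in place of carboxy, or a dimethylamino group in place of amino, would stand against compound 3 and compound 4 at this place.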